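The source may hold more compounds than are shown below. What is called first, only, known or untested is meant among the compounds shown, and "the series" means these compounds.

Three amides share a common bicyclic core. Compound 1 `COc1ccc(NC(=O)c2cc(=O)[nH]c3cc(Br)ccc23)cc1` and compound 2 `O=C(Nc1ccc(C(F)(F)F)cc1)c1cc(=O)[nH]c2cc(Br)ccc12` differ only by methoxy in place of trifluoromethyl on an aromatic carbon. In a functional assay on KYSE-410 cells (Homo sapiens) for antiproliferative activity, read by MTT assay, with a stated time of 72 h (a lower number here means a stronger inhibitor, a higher number a weaker inhibitor), compound 1 gives a limit of > 20000 nM, not a number. Compound 2 likewise gives only a limit, > 20000 nM. The step that the two limits leave unreadable from compound 2 to compound 1 therefore cannot be read, because of the limit of > 20000 nM in this assay, at which 2 of the 3 values shown sit. For the measured compounds named here, compound 3 `O=C(Nc1cc(F)cc(F)c1)c1cc(=O)[nH]c2cc(C(F)(F)F)ccc12` is the only one with a measured value, 17900 nM in this assay; how its core differs from that of compound 2 is not broken down here. Compound 4 `COc1ccc2c(C(=O)Nc3cc(F)cc(F)c3)cc(=O)[nH]c2c1` arises from compound 3 by methoxy in place of trifluoromethyl on an aromatic carbon, the same kind of change as from compound 2 to compound 1, though here on the fused ring, meta and para to a fused ring, rather than para to a large group. Since the earlier step is unreadable, the expected step of a 1.4-fold higher number from compound 3 to compound 4 (0.15 log units; within the scatter) rests only on compound 3 at 17900 nM. Compound 4 is estimated at 25000 nM, between 8000 nM and 80000 nM.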

Compound 4, half-maximal inhibitory concentration: > 20000 nM
Compound 4 gave a limit, no number; the forecaster's own chance of this, stated with the estimate: 60%; the middle value does not contradict the limit.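

With methoxy in place of trifluoromethyl on an aromatic carbon of the fused ring system, the data give an at least 1.1-fold higher number from compound 3 to compound 4 (0.04 log units; that floor lies within the scatter) in this assay, and this is only a floor, since compound 4 gives a limit and not a number. From the compounds shown here alone, the change therefore did not give compound 4 a measured value, but the true size of the step remains unknown. The matching step on the other core cannot be read, so nothing shows whether the change carries from one core to another, because most values are limits: the limit of > 20000 nM in this assay, at which 3 of the 4 values shown sit.

The compounds shown leave open what would bring a number in this series well clear of that limit. Going by these compounds, whether an amine or a carboxylic acid in place of the methoxy of compound 4 would give a readable value also stays open.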